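Swapping the aryl group on a sulfonamide nitrogen

The source may report more compounds than this note shows. Statements on the series, on what has been measured and on what is new or still open speak of the compounds shown alone.

Of the compounds shown here, three sharing one core have been measured in a functional assay on M21 cells (Homo sapiens) for antiproliferative activity, read by sulforhodamine B assay, with a stated time of 48 h; on this read-out lower numbers stand for stronger inhibition and higher numbers for weaker inhibition. Compound 1 `O=C1NCCN1c1ccc(S(=O)(=O)Nc2ccc(F)c(F)c2)cc1` carries a 3,4-difluorophenyl on the sulfonamide nitrogen, and in this assay compound 1 gives 220 nM, the lowest of the two numbers that were obtained. Compound 3 `CCCCCc1ccc(NS(=O)(=O)c2ccc(N3CCNC3=O)cc2)cc1` carries a pentyl-bearing phenyl at that nitrogen, and in this assay compound 3 gives 870 nM, a weaker result than compound 1 by a margin beyond the usual scatter. Compound 2 `CC(C)(C)c1cc(NS(=O)(=O)c2ccc(N3CCNC3=O)cc2)cc(C(C)(C)C)c1` carries two tert-butyl groups on its phenyl; in this assay compound 2 reaches only the limit of > 1000 nM, so no number is known for it, and the limit of > 1000 nM in this assay, at which 1 of the 3 values shown sits, records that one of the three values sits at this limit.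

Compound 4 `COc1cccc(NS(=O)(=O)c2ccc(N3CCNC3=O)cc2)c1` is the next compound. It differs from compound 1 in one place: 3-methoxyphenyl in place of 3,4-difluorophenyl on a sulfonamide nitrogen.

For the measured compounds named here, no measured pair differs in only one place, so the size of this step cannot be read from the data. The larger aryl groups of compound 2 and compound 3 gave weaker results than compound 1, and a 3-methoxyphenyl is expected to land between them, probably a modest weakening of a 1.8-fold higher number from compound 1 to compound 4 (0.26 log units; within the scatter). Compound 4 is therefore expected to give about 400 nM in this assay, with a likely range from 150 nM to 1100 nM.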

Compound 4, half-maximal inhibitory concentration: 65 nM
For compound 4 the middle estimate is 6.2-fold (0.79 log units) above the measured one; measured number below the stated range.
By their numbers in this assay, from the lowest: compound 4; then compound 1; then compound 3. At a limit, above all of these: compound 2.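

In this assay, for the compounds shown here, the swap to 3-methoxyphenyl on the sulfonamide nitrogen gives a 3.4-fold lower number from compound 1 to compound 4 (0.53 log units; beyond the scatter), the first single change at this position whose size can be read from measured numbers, and it makes compound 4 the lowest of the measured values so far. The two aryl groups hold the same number of heavy atoms, and each has one six-membered aromatic ring of carbon only, so this position responds to what is attached to the ring and not only to how many heavy atoms the group holds; the main counted difference is that the entering group brings a hydrogen-bond acceptor, while the leaving group has none. Nothing among the data shown accounts for the stronger result of compound 4.

From the compounds shown here alone, what stays open is which part of the change matters, since the two fluorines leave and the methoxy enters in one step. Going by these compounds, an unsubstituted phenyl, a 3-fluorophenyl, a 3-hydroxyphenyl or a 3-ethoxyphenyl at this nitrogen would help to separate those two parts, and how any of them compares with compound 4 remains unknown here.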